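This account rests on a few compounds, and the source may have more. Where it says the series, first, only, none or still open, it means among the compounds named here.

Compound 1, `COc1cc(-c2cc3c(O)nc(C)nc3cc2C(C)C)ccc1Cl`, gives 14 nM in a functional assay for inhibition of transient receptor potential cation channel subfamily V member 1 (Homo sapiens), read by fluorescence and calcium flux; on this read-out lower numbers stand for stronger inhibition and higher numbers for weaker inhibition. Compound 2, `Cc1nc(O)c2cc(-c3ccc(Cl)c(OCC(=O)O)c3)c(C(C)C)cc2n1`, carries a carboxy on the saturated chain carbon bound to an oxygen on the aromatic ring where compound 1 has a hydrogen. For compound 2 this assay reports only a limit, > 1000 nM. Going by the values given here, the step of an at least 71-fold higher number from compound 1 to compound 2 (1.85 log units; beyond the scatter) is therefore known only as a bound, marked by the limit of > 1000 nM in this assay, at which 1 of the 2 values shown sits, and it is the single measured step that bears on the next compound. Compound 3, `CCOc1cc(-c2cc3c(O)nc(C)nc3cc2C(C)C)ccc1Cl`, is not yet measured; it differs from compound 2 by methyl in place of carboxy on a saturated chain carbon bound to an oxygen on an aromatic ring, so that compound 3 reads as compound 1 with an ethoxy in place of the methoxy. Among the compounds with values here, since the one measured step shows that adding the carboxy to compound 1 raised the number far beyond the scatter, its removal in compound 3 is expected to reverse most of that rise, leaving only the added methyl as an untested change. Compound 3 is thus expected to give 20 nM, between 5 nM and 80 nM, a step of an at least 50-fold lower number from compound 2 to compound 3 (1.69 log units; beyond the scatter) estimated in the direction of stronger inhibition.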

Compound 3, half-maximal inhibitory concentration: 12 nM
The estimate for compound 3 lay 1.7-fold (0.22 log units) above the measured number, and the stated range covers the measured number.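

In this assay, the change from the methoxy of compound 1 to the ethoxy of compound 3 gives a 1.2-fold lower number from compound 1 to compound 3 (0.07 log units; within the scatter), so a methyl on the saturated chain carbon bound to an oxygen on an aromatic ring leaves the read-out within the scatter of the hydrogen it replaces. The same place carrying a carboxy stands far apart, as the exchange of that carboxy for methyl gives an at least 83-fold lower number from compound 2 to compound 3 (1.92 log units; beyond the scatter), which shows that the weak result of compound 2 goes with the carboxy and not with any added group at this carbon. The size of that step is known only as a bound, as compound 2 is read only as a limit of the assay: the limit of > 1000 nM in this assay, at which 1 of the 3 values shown sits.

With only hydrogen, methyl and carboxy compared at this carbon, the compounds shown leave open whether an amine, a hydroxy or a longer chain there would keep the read-out of compound 1 and compound 3 or move it towards that of compound 2. They also leave open how far the true number for compound 2 lies beyond its limit, and so the full size of the carboxy step.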